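From pyridin-4-yl to 2-aminopyridin-4-yl

The source may report more compounds than this note shows. Statements on the series, on what has been measured and on what is new or still open speak of the compounds shown alone.

In a functional assay for inhibition, with Homo sapiens as the target (a higher number here means a weaker inhibitor, a lower number a stronger inhibitor), compound 2 (`O=C(NC[C@H](NS(=O)(=O)c1ccccc1)C(=O)O)c1cc2cc(OCc3ccncc3)ccc2[nH]1`) gives 280 nM as the higher of the two measured numbers, against compound 1 (`O=C(NC[C@H](NS(=O)(=O)c1ccccc1)C(=O)O)c1cc2cc(OCC3CCNCC3)ccc2[nH]1`) at 13 nM in the same read-out. Compound 3 (`Nc1cc(COc2ccc3[nH]c(C(=O)NC[C@H](NS(=O)(=O)c4ccccc4)C(=O)O)cc3c2)ccn1`) carries 2-aminopyridin-4-yl in place of pyridin-4-yl, with amino in place of hydrogen on an aromatic carbon. For the measured compounds named here, the one measured step bearing on this, a 22-fold higher number from compound 1 to compound 2 (1.33 log units; beyond the scatter) at the same group, is large, but it is a different change, so only a moderate step to a lower number is expected. The estimated step is a 4.0-fold lower number from compound 2 to compound 3 (0.60 log units; beyond the scatter) in this assay as it stands. For compound 3 the expected value is 70 nM within a range of 15 nM to 300 nM in this assay.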

Compound 3, half-maximal inhibitory concentration: 45 nM
For compound 3 the middle estimate is 1.6-fold (0.19 log units) above the measured one, within the range that was stated.
By their numbers in this assay, from the lowest: compound 1; then compound 3; then compound 2.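

In this assay, amino on the aromatic carbon next to the ring nitrogen wins back part of what the pyridin-4-yl group gives up, with a 6.2-fold lower number from compound 2 to compound 3 (0.79 log units; beyond the scatter) as the gain at this position. The saturated group keeps an edge, since a 3.5-fold higher number from compound 1 to compound 3 (0.54 log units; beyond the scatter) still separates 2-aminopyridin-4-yl from piperidin-4-yl on the same chain. No measurement at hand accounts for either step. Open, on these data alone, is whether a methyl, a hydroxyl or a methylamino group in place of the amino would do the same, and whether the gain depends on this ring carbon.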